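Adding a chlorine to the urea tail of compound 1

A few compounds are considered here, and "the series" means these few. Any claim that something is new, unique, unknown or untested is made for them only; others in the source may bear on it.

Compound 1 `O=C(Nc1cccc(-n2cc(-c3ccncc3)c(-c3ccc(Cl)c(O)c3)n2)c1)Nc1cccc(C(F)(F)F)c1` is tested in a functional assay on NCI-H322M cells (Homo sapiens) for inhibition, read by sulforhodamine B assay, with a stated time of 48 h (a higher number here means a weaker inhibitor of growth, a lower number a stronger inhibitor of growth), where compound 1 gives 6410 nM. Within the data shown here, of the two compounds measured it stands at the highest number; its only neighbour, compound 2 `COc1cc(-c2nn(-c3cccc(NC(=O)Nc4cccc(C(F)(F)F)c4)c3)cc2-c2ccncc2)ccc1Cl`, gives 1210 nM. Among the measured compounds shown here, the one step between measured compounds, a 5.3-fold lower number from compound 1 to compound 2 (0.72 log units; beyond the scatter), concerns a methyl placed on the phenol oxygen, a part of the molecule that compound 3 leaves untouched.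

Compound 3 `O=C(Nc1cccc(-n2cc(-c3ccncc3)c(-c3ccc(Cl)c(O)c3)n2)c1)Nc1ccc(Cl)c(C(F)(F)F)c1` differs from compound 1 by chloro in place of hydrogen on an aromatic carbon. For the measured compounds named here, no measured step touches this end of the molecule, so nothing measured here tells how much a chloro at that place shifts the number; the only guide is where compound 1 stands. On that basis a small improvement is the expectation, and the estimated step is a 1.8-fold lower number from compound 1 to compound 3 (0.26 log units; within the scatter). Compound 3 is therefore expected to give about 3500 nM, with a range from 1200 nM to 10000 nM.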

Compound 3, concentration for 50% growth inhibition: 1090 nM
The estimate for compound 3 lay 3.2-fold (0.51 log units) above the measured number, outside the stated range (below it).
By their numbers in this assay, from the lowest: compounds 3 and 2 (each within the scatter of the next); then compound 1.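

Chloro in place of hydrogen on the 3-(trifluoromethyl)phenyl ring gives a 5.9-fold lower number from compound 1 to compound 3 (0.77 log units; beyond the scatter) in this assay, so a single added atom at this place moves the number beyond the scatter. Among these compounds, this is the first measured sign that the tail end of the urea, and not only the phenol oxygen, can shift growth inhibition in these cells. No available measurement explains why this chloro has such an effect.

Whether the gain is particular to chlorine stays open: none of the compounds shown carries a fluoro, a methyl or an amine at this place. Also open, as far as these compounds go, is whether the same chloro would shift the number in the same direction on compound 2, which carries the methyl on its phenol oxygen.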